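The compounds below may be only part of what the source reports. "The series", "measured", "known", "first", "only" and "open" are said of these compounds alone.

In a functional assay on EBC-1 cells (Homo sapiens) for inhibition, read by sulforhodamine B assay, with a stated time of 72 h (a lower number here means a stronger inhibitor, a higher number a weaker inhibitor), compound 3 (`CN(C)CCCOC(=O)Nc1cccc(Cn2nc(-n3ccc4ccc(F)cc43)ccc2=O)c1`) gives <= 1000 nM as a limit and not a number. Compound 2 (`CN(C)CCCCOC(=O)Nc1cccc(Cn2nc(-n3ccc4ccc(F)cc43)ccc2=O)c1`) gives <= 1000 nM as a limit too. Compound 1 (`CN(C)CCCCOC(=O)Nc1cccc(Cn2nc(Nc3ccccc3)ccc2=O)c1`) gives > 10000 nM as a limit too. From the compounds shown here alone, compound 3 thus stands at the limit of <= 1000 nM in this assay, at which 2 of the 3 values shown sit, and its exact position is unknown.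

Compound 4 (`CN1CCN(CCCCOC(=O)Nc2cccc(Cn3nc(-n4ccc5ccc(F)cc54)ccc3=O)c2)CC1`) differs from compound 3 by (4-methylpiperazin-1-yl)methyl in place of dimethylamino on a saturated chain carbon, three bonds along the chain from an oxygen next to a carbonyl group with (4-methylpiperazin-1-yl)methyl in place of dimethylamino on a saturated chain carbon, three bonds along the chain from an oxygen next to a carbonyl group. For the measured compounds named here, the only measured change at that place is a step that the two limits leave unreadable from compound 2 to compound 3 and it offers no size to carry over. The other measured change, an at least 10-fold lower number from compound 1 to compound 2 (1.00 log units; beyond the scatter) with 6-fluoro-1H-indol-1-yl in place of anilino, lies elsewhere, and compound 4 keeps the 6-fluoro-1H-indol-1-yl group.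

In this assay no step beyond the scatter is expected, and the estimated move is a step that the limit leaves unreadable from compound 3 to compound 4 with no supported direction. Compound 4 is estimated at 500 nM with an expected range of 80 nM to 2500 nM in this measurement.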

Compound 4, half-maximal inhibitory concentration: <= 100 nM
Compound 4: no number, only a limit; the forecaster's own chance of this, stated with the estimate: 60%; middle value at least 5.0-fold (0.69 log units) from the limit.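

In this assay compound 4 gives <= 100 nM, a limit and not a number. For the compounds shown here, compound 2 and compound 3 also stand at limits, and no step to compound 4 can be read. The compounds shown leave open the size and direction of the change from dimethylamino to (4-methylpiperazin-1-yl)methyl.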